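The compounds below may be only part of what the source reports. "The series", "measured", "known", "first", "only" and "open" are said of these compounds alone.

Measured compounds:
compound 1 `O=C(Nc1cc(C(F)(F)F)ccc1N1CCCC1)c1cccnc1Cl` — "not active" (no number reported)
compound 2 `O=C(Nc1cc(C(F)(F)F)ccc1N1CCCCC1)c1cccnc1Cl` — "not active" (no number reported)
compound 3 `O=C(Nc1cc(C(F)(F)F)ccc1NC1CCCCC1)c1cccnc1` — 48300 nM

In a functional assay on HL-60 cells (Homo sapiens) for cytotoxicity, read by MTT assay, with a stated time of 48 h (a higher number here means a weaker inhibitor, a lower number a stronger inhibitor), compound 1 was recorded as "not active" (no number reported), with no number behind it. Compound 2 stands the same way, and in this assay compound 2 is also reported as "not active" (no number reported). Only one of the three measured compounds carries a number: in this assay compound 3 gives 48300 nM, a weak result. For the measured compounds named here, compound 3 differs from compound 1 in more than one place, so no single step between them can be read off; the two values show only that one is inactive and the other very weak.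

Compound 4 `O=C(Nc1cc(C(F)(F)F)ccc1N1CCCC1)c1ccncc1` has not yet been tested. It differs from compound 1 in one place: pyridin-4-yl in place of 2-chloropyridin-3-yl on a carbonyl carbon. No step of this kind is found among the measured compounds, so nothing shown here says in which direction this change moves the result. Given that compound 1 is reported as "not active" (no number reported) and that the one numbered compound, compound 3, sits at 48300 nM, compound 4 is expected to remain weak, and there is a real chance that no number at all is reported for it. If a number is obtained, compound 4 is estimated at 70000 nM, with a range from 20000 nM to 200000 nM.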

Compound 4, half-maximal inhibitory concentration: "not active" (no number reported)
The entry for compound 4 holds no number; no gap can be computed for the estimate.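

In this assay, for the compounds shown here, compound 1 gives "not active" (no number reported) and compound 4 gives "not active" (no number reported) as well, so no step between the two can be read. No measured evidence bears on this result. The compounds shown leave open whether exchanging 2-chloropyridin-3-yl for pyridin-4-yl on the carbonyl carbon changes the activity at all.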